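A few compounds are considered here, and "the series" means these few. Any claim that something is new, unique, unknown or untested is made for them only; others in the source may bear on it.

Compound 1 `CC(C(=O)NCc1ccc(C(F)(F)F)nc1N1CCCC1)c1ccc(NS(C)(=O)=O)c(F)c1` is the more potent of the two measured compounds: in a functional assay on CHO-K1 cells for antagonist activity at transient receptor potential cation channel subfamily V member 1 (Homo sapiens), read by FLIPR (on this read-out higher numbers stand for weaker inhibition and lower numbers for stronger inhibition), compound 1 gives 0.6 nM, while compound 2 `C[C@H](C(=O)NCc1ccc(C(F)(F)F)nc1N1CC[C@@H](OCc2ccccc2)C1)c1ccc(NS(C)(=O)=O)c(F)c1` gives 1.4 nM, a gap beyond the usual scatter. Compound 3 `CC(=O)OC1CCN(c2nc(C(F)(F)F)ccc2CNC(=O)C(C)c2ccc(NS(C)(=O)=O)c(F)c2)CC1` has not yet been measured. It differs from compound 1 in one place (4-acetoxypiperidin-1-yl in place of pyrrolidin-1-yl on an aromatic carbon). Going by the values given here, no single step between measured compounds is available for this change. Since compound 2, with its larger substituted ring, gives 1.4 nM, a modest weakening is expected, so that from compound 1 to compound 3 the step is expected to be a 2.5-fold higher number from compound 1 to compound 3 (0.40 log units; beyond the scatter). Compound 3 is therefore estimated at 1.5 nM, in a range from 0.4 nM to 6 nM.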

Compound 3, inhibition constant: 4 nM
Estimate against measurement, compound 3: 2.7-fold (0.43 log units) below; low and high end bracket the measured number.
By their numbers in this assay, from the lowest: compound 1; then compound 2; then compound 3.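

In this assay, replacing pyrrolidin-1-yl with 4-acetoxypiperidin-1-yl next to the ring nitrogen gives a 6.7-fold higher number from compound 1 to compound 3 (0.82 log units; beyond the scatter), so this position accepts the larger group but at a clear cost in potency. The exchange changes the ring size and adds the acetoxy group together, so this step cannot separate the two changes. Nothing measured here accounts for the loss. Going by these compounds, it remains open how the unsubstituted piperidine ring would compare, and whether a hydroxyl group or an amine at the 4-position would behave like the acetoxy group.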